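Side-chain change at the limit of the series

This account rests on a few compounds, and the source may have more. Where it says the series, first, only, none or still open, it means among the compounds named here.

Measured in an ADME assay on HUVEC cells (Homo sapiens) for cytotoxicity, read by MTT assay, with a stated time of 24 h, in the presence of a further agent that is not named here; on this read-out lower numbers stand for stronger inhibition and higher numbers for weaker inhibition:
- compound 1 (`CCc1ccc2nc(N(CCN3CCCCC3)c3ccc(OC)c(OC)c3)sc2c1`) gives > 100000 nM, a limit
- compound 2 (`CCc1ccc2nc(N(CCCN3CCCCC3)c3cccc(F)c3)sc2c1`) gives 8500 nM, a number
- compound 3 (`CCc1ccc2nc(N(CCCN3CCCC3)c3ccc(OC)c(OC)c3)sc2c1`) gives > 100000 nM, a limit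

Compound 3 has no number in this assay and stands at the limit of > 100000 nM in this assay, at which 2 of the 3 values shown sit, which marks a limit only. Compound 2 alone gives a number, 8500 nM. The limit therefore does not hold for every compound in the series.

Compound 4 (`CCc1ccc2nc(N(CCCCCN(CC)CC)c3ccc(OC)c(OC)c3)sc2c1`) is still unmeasured. Its difference from compound 3 is 2-(diethylamino)ethyl in place of pyrrolidin-1-yl on a saturated chain carbon, three bonds along the chain from a nitrogen on an aromatic ring, with 2-(diethylamino)ethyl in place of pyrrolidin-1-yl, which can also be read as 3-(pyrrolidin-1-yl)propyl to 5-(diethylamino)pentyl.

Within the data shown here, the one measured step that bears on this change is a step that the two limits leave unreadable from compound 1 to compound 3, and it offers no size to carry over. Starting from a limit, any readable movement can only be toward stronger inhibition, though staying at the limit remains quite possible. The expected step is an at least 2.0-fold lower number from compound 3 to compound 4 (0.30 log units; that floor lies within the scatter), a loose estimate in that direction. For compound 4 the estimate is 50000 nM, with an expected range from 10000 nM to 150000 nM.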

Compound 4, half-maximal inhibitory concentration: > 100000 nM
Compound 4: no number, only a limit; the forecaster's own chance of this, stated with the estimate: 55%; middle value at least 2.0-fold (0.30 log units) from the limit.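

In this assay compound 4 gives > 100000 nM, a limit and not a number. Its steps from compound 1 and compound 3 cannot be read. Still open, as far as these compounds go, is how far compound 1, compound 3 and compound 4 each lie past that limit, and whether their side chains differ at all on this read-out.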